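A few compounds are considered here, and "the series" means these few. Any claim that something is new, unique, unknown or untested is made for them only; others in the source may bear on it.

Measured so far:
Compound 1 `CCNC(=O)c1ccc(-c2nnc(C3(c4ccc(Cl)cc4)CCC3)n2C)cc1` gives 0% in a functional assay on the whole organism (strain ICR) for inhibition, with Mus musculus as the target, read by scintillation counting, with a stated time of 16 h, at a dose of 10 mg/kg by the oral route; a lower number here means less inhibition, a higher number more inhibition at the dose given (going by the name of the read-out).
Compound 2 `Cc1noc(C)c1-c1ccc(-c2nnc(C3(c4ccc(Cl)cc4)CCC3)n2C)cc1` gives 9% in this assay.

Within the data shown here, compound 2 carries the higher of the two numbers, with compound 1 as its only neighbour, but the step of a number 9 percentage points higher from compound 1 to compound 2 (within the scatter) lies within the scatter, so the two compounds are not separated by this assay.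

Compound 3 `Cn1c(-c2ccc(C(=O)NC(C)(C)C)cc2)nnc1C1(c2ccc(Cl)cc2)CCC1` is the next candidate. Relative to compound 2 the change is (tert-butyl)carbamoyl in place of 3,5-dimethyl-1,2-oxazol-4-yl on an aromatic carbon. Among the measured compounds shown here, the one measured step that bears on this is the reverse one: from compound 1 to compound 2 a carbamoyl on that aromatic carbon was exchanged for the 3,5-dimethyl-1,2-oxazol-4-yl group, and the shift was a number 9 percentage points higher from compound 1 to compound 2 (within the scatter), inside the scatter. For the measured compounds named here, compound 3 returns to a carbamoyl, now (tert-butyl)carbamoyl rather than ethylcarbamoyl; no measured pair tells what the larger alkyl on the amide nitrogen does, so only the reversal of the small step is available. The expected change in this assay is therefore a number 6 percentage points lower from compound 2 to compound 3 (within the scatter), i.e. none beyond the scatter. For compound 3 the estimate is 3%, with a range of -8% to 18%.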

Compound 3, a percentage reported as inhibition, in the whole organism at one dose (the size of the read-out at that dose, not a potency): 5%
Beside the measured number, compound 3's estimate is 2 percentage points below it; the range from low to high includes it.
By their numbers in this assay, from the lowest: compounds 1, 3 and 2 (each within the scatter of the next).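

Among these compounds, with tert-butyl in place of ethyl on an amide-type nitrogen, the change is a number 5 percentage points higher from compound 1 to compound 3 (within the scatter) and so the two amides are not separated in this assay, which gives the first reading of the alkyl group on the amide itself. The exchange of the 3,5-dimethyl-1,2-oxazol-4-yl ring for the ring-free (tert-butyl)carbamoyl group, which adds a hydrogen-bond donor, gives a number 4 percentage points lower from compound 2 to compound 3 (within the scatter) and so these two compounds are not separated either; the three groups on this aromatic carbon, para to a large group, thus all read alike at this single oral dose. Nothing measured gives a reason for this flat result.

The compounds shown leave open whether any group at this position can move the number beyond the scatter, for example a carboxylic acid, a primary amine or a longer chain on the amide nitrogen. Since all three numbers lie close together at the low end of the percentage scale, they also leave open whether a change elsewhere on the shared core would be needed before differences at this position can be read.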